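Amine alkyl change on the longer-chain amide

This account rests on a few compounds, and the source may have more. Where it says the series, first, only, none or still open, it means among the compounds named here.

Of the compounds shown here, three of the shared core have been measured in a functional assay on the whole organism for inhibition of sodium-dependent dopamine transporter (Mus musculus); on this read-out higher numbers stand for an effect only at larger amounts of compound and lower numbers for an effect already at smaller amounts. Compound 1 `CN1Cc2c(NC(=O)OCc3ccccc3)cccc2C(c2ccccc2)C1` gives 25 mg/kg, compound 2 `CC(C)NCC(=O)Nc1cccc2c1CN(C)CC2c1ccccc1` gives about 30 mg/kg, and compound 3 `CC(C)NCCC(=O)Nc1cccc2c1CN(C)CC2c1ccccc1` gives about 200 mg/kg, the highest number of the three; the steps of a 6.7-fold higher number from compound 2 to compound 3 (0.82 log units; beyond the scatter) and an 8.0-fold higher number from compound 1 to compound 3 (0.90 log units; beyond the scatter) both lie beyond the scatter, whereas a 1.2-fold higher number from compound 1 to compound 2 (0.08 log units; within the scatter) does not. Compound 4 `CCCCNCCC(=O)Nc1cccc2c1CN(C)CC2c1ccccc1` differs from compound 3 by butyl in place of isopropyl on an amine nitrogen. Going by the values given here, none of the measured steps alters the amine substituent; all three concern the group on the carbonyl carbon, so they give no direct guide to this change. Among the compounds with values here, with no precedent, the expected step of no change at the digits printed from compound 3 to compound 4 (within the scatter) is put at none beyond the scatter. Compound 4 is therefore estimated at 200 mg/kg, with a range from 80 mg/kg to 500 mg/kg.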

Compound 4, dose for half-maximal effect: > 60 mg/kg
Compound 4: a limit, no number; the forecaster's own chance of this, stated with the estimate: 10%; the middle value is on the limit's open side.
By their numbers in this assay, from the lowest: compounds 1 and 2 (each within the scatter of the next); then compound 3.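

Compound 4 stands in this assay as a limit, not a number: the limit of > 60 mg/kg in this assay, at which 1 of the 4 values shown sits.

The step for butyl in place of isopropyl on an amine nitrogen, and any step from compound 3, cannot be read, so this change has no measured size. The readable steps are an at least 2.4-fold higher number from compound 1 to compound 4 (0.38 log units; beyond the scatter) and an at least 2.0-fold higher number from compound 2 to compound 4 (0.30 log units; that floor lies within the scatter), and only the first of these floors clears the scatter.

From the compounds shown here alone, whether butyl and isopropyl differ at this amine nitrogen remains open. So does how a longer chain such as hexyl, or dimethylamino in place of butylamino, would read in this assay.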